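This account rests on a few compounds, and the source may have more. Where it says the series, first, only, none or still open, it means among the compounds named here.

In a functional assay on PC-3 cells (Homo sapiens) for cytotoxicity (on this read-out lower numbers stand for stronger inhibition of growth and higher numbers for weaker inhibition of growth), compound 2 `O=C(Nc1cc(C(F)(F)F)ccc1C(F)(F)F)C1Cc2ccccc2N1` gives 794 nM, the only numerical result in this set. Compound 1 `Cc1ccc(S(=O)(=O)N2c3ccccc3CC2C(=O)Nc2cc(Cl)cc(Cl)c2)cc1` reaches only the assay limit, > 10000 nM. Compound 3 `CC(C)(C)OC(=O)N1c2ccccc2CC1C(=O)Nc1cc(C(F)(F)F)ccc1C(F)(F)F` has not yet been tested; it differs from compound 2 by tert-butoxycarbonyl in place of hydrogen on a nitrogen on an aromatic ring in a ring. Compound 1, whose ring nitrogen also carries a substituent, sits at the limit of > 10000 nM in this assay, at which 1 of the 2 values shown sits. On that showing the step of a 6.3-fold higher number from compound 2 to compound 3 (0.80 log units; beyond the scatter) is expected to weaken inhibition of growth well beyond the usual scatter. Compound 3 is therefore estimated at 5000 nM, with a likely range from 1500 nM to 20000 nM, and a fair chance that only a limit is reported.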

Compound 3, concentration for 50% growth inhibition: 838 nM
Beside the measured number, compound 3's estimate is 6.0-fold (0.78 log units) above it, outside the stated range (below it).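

Measured in this assay, tert-butoxycarbonyl in place of hydrogen on this nitrogen gives a 1.1-fold higher number from compound 2 to compound 3 (0.02 log units; within the scatter) and so shows that a substituent at this place does not by itself take a compound to the assay limit. Compound 1 remains at a limit, and it differs from compound 3 in more than one place, so its reading cannot be set against this step: the limit of > 10000 nM in this assay, at which 1 of the 3 values shown sits. On these data alone, whether a methyl or acetyl group, or a chain ending in an amine, on this nitrogen reads the same stays open. So does the reading of a sulfonyl group here with the two trifluoromethyl groups of compound 3 kept.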